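Changing the group on the carbonyl of compound 1

The source may report more compounds than this note shows. Statements on the series, on what has been measured and on what is new or still open speak of the compounds shown alone.

Compound 1, with structure `COc1cc(-c2nn(-c3cccc(NC(=O)c4cccc(C(F)(F)F)c4)c3)cc2-c2ccncc2)ccc1Cl`, was tested in a functional assay on ACHN cells (Homo sapiens) for inhibition, read by sulforhodamine B assay, with a stated time of 48 h (a lower number here means a stronger inhibitor of growth, a higher number a weaker inhibitor of growth), and gives 1890 nM, the highest of the two numbers recorded so far. Compound 2, with structure `O=C(Nc1cccc(-n2cc(-c3ccncc3)c(-c3ccc(Cl)c(O)c3)n2)c1)Nc1cc(C(F)(F)F)cc(C(F)(F)F)c1`, carries an amino-linked aryl on its carbonyl and differs elsewhere as well; in this assay compound 2 gives 624 nM, a lower number than compound 1 and beyond the usual scatter. Compound 3, with structure `COc1cc(-c2nn(-c3cccc(NC(=O)Nc4ccc(Cl)c(C(F)(F)F)c4)c3)cc2-c2ccncc2)ccc1Cl`, has not yet been measured. It differs from compound 1 in one place: (4-chloro-3-(trifluoromethyl)phenyl)amino in place of 3-(trifluoromethyl)phenyl on a carbonyl carbon. Among the measured compounds shown here, no step between measured compounds isolates this change, so the expectation rests only on the two values shown. The step from compound 1 to compound 3 is estimated to lower the number by a 3.4-fold lower number from compound 1 to compound 3 (0.54 log units; beyond the scatter), a modest move in the direction of stronger inhibition. Compound 3 is expected to give about 550 nM in this assay, with a range from 150 nM to 2000 nM.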

Compound 3, concentration for 50% growth inhibition: 1100 nM
The estimate for compound 3 lay 2.0-fold (0.30 log units) below the measured number; the range from low to high includes it.
By their numbers in this assay, from the lowest: compounds 2, 3 and 1 (each within the scatter of the next, the first and the last beyond it).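

In this assay, a 1.7-fold lower number from compound 1 to compound 3 (0.24 log units; within the scatter), the step that puts (4-chloro-3-(trifluoromethyl)phenyl)amino in place of 3-(trifluoromethyl)phenyl on a carbonyl carbon. Among the compounds shown here, this is the first direct reading at this position, and it shows that this change, which adds a nitrogen, a chlorine and a hydrogen-bond donor, does not separate the two compounds in growth inhibition. No measurement shown here accounts for this result.

The amino link and the chlorine enter together, so this step cannot show what each does alone, and a pair differing only in the amino link or only in the chlorine would be needed to tell them apart. Going by these compounds, it also remains open how this carbonyl carbon would respond to a quite different group, such as a morpholine or a simple alkyl chain.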